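This account rests on a few compounds, and the source may have more. Where it says the series, first, only, none or still open, it means among the compounds named here.

In an in vivo functional assay on the whole organism for inhibition, with Rattus norvegicus as the target (a lower number here means that less compound is needed, a higher number that more compound is needed for the effect), compound 1 `CCCc1nc(C)c(CC(=O)O)c(=O)n1Cc1ccc(-c2ccccc2-c2nnn[nH]2)cc1` stands as "not determined" (no result reported) and so offers no comparison. Compound 2 `CCCCc1nc(C)c(CC(=O)N2CCCC2)c(=O)n1Cc1ccc(-c2ccccc2-c2nnn[nH]2)cc1` gives 0.056 mg/kg there, the only number shown, so it cannot yet be placed against any other compound. Compound 3 `CCCCc1nc(C)c(CCC(=O)N2CCSCC2)c(=O)n1Cc1ccc(-c2ccccc2-c2nnn[nH]2)cc1` departs from compound 2 by one change ((thiomorpholin-4-yl)carbonyl)methyl in place of (pyrrolidin-1-yl)carbonyl on a saturated chain carbon bound to an aromatic carbon in which ((thiomorpholin-4-yl)carbonyl)methyl takes the place of (pyrrolidin-1-yl)carbonyl on a saturated chain carbon bound to an aromatic carbon. Among the compounds with values here, no measured step is available to gauge this change in this assay and the expectation therefore stays broad. Starting from compound 2 at 0.056 mg/kg a modest rise in the dose needed is expected, little beyond the usual scatter. An estimated 2.1-fold higher number from compound 2 to compound 3 (0.33 log units; beyond the scatter) is what this expectation amounts to. For compound 3 the estimated dose is 0.12 mg/kg with an expected range from 0.025 mg/kg at the low end to 0.6 mg/kg at the high end.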

Compound 3, dose for half-maximal effect: 0.204 mg/kg
The estimate for compound 3 lay 1.7-fold (0.23 log units) below the measured number, and the stated range covers the measured number.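

In this assay, the first step readable at this position is a 3.6-fold higher number from compound 2 to compound 3 (0.56 log units; beyond the scatter), so the number does respond to a change here, though the response is modest and compound 3 still gives a measurable dose. The step cannot be divided, since a six-membered non-aromatic ring with 2 hetero atoms replaces a five-membered one with 1 hetero atom while ((pyrrolidin-1-yl)carbonyl)methyl also gives way to the longer 2-((thiomorpholin-4-yl)carbonyl)ethyl. Nothing available explains the rise in the number.

The compounds shown leave open how much of the step belongs to the ring and how much to the chain, which a pyrrolidine amide on the ethyl chain or a thiomorpholine amide on the methyl chain would separate. From the compounds shown here alone, how a morpholine amide or a primary amide would behave at this place also remains open.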